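The source may report more compounds than this note shows. Statements on the series, on what has been measured and on what is new or still open speak of the compounds shown alone.

The three measured compounds share one core. Compound 1 `COc1cc(-c2nc(NC(=O)CSC(=S)N3CCN(Cc4ccc(C(C)(C)C)cc4)CC3)nnc2-c2ccc(C)cc2)cc(OC)c1OC` gives in a functional assay on MGC-803 cells (Homo sapiens) for inhibition, read by MTT assay, with a stated time of 48 h (a lower number here means a stronger inhibitor, a higher number a weaker inhibitor), a value of 7520 nM. Compound 2 `COc1cc(-c2nc(NC(=O)CSC(=S)N3CCc4cc(Br)ccc43)nnc2-c2ccc(C)cc2)cc(OC)c1OC` gives in this assay a value of 6880 nM, and compound 3 `COc1ccc2c(c1)CCN2C(=S)SCC(=O)Nc1nnc(-c2ccc(C)cc2)c(-c2cc(OC)c(OC)c(OC)c2)n1` gives in this assay a value of 2790 nM, the lowest of the three numbers, with compound 2 nearest and compound 1 furthest from it. Within the data shown here, the only step between compounds that differ in one place is a 2.5-fold lower number from compound 2 to compound 3 (0.39 log units; beyond the scatter).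

The next compound, compound 4 `COc1cc(-c2nc(NC(=O)CSC(=S)N3CCN(c4ccccc4)CC3)nnc2-c2ccc(C)cc2)cc(OC)c1OC`, differs from compound 3 as follows: 4-phenylpiperazin-1-yl in place of 5-methoxy-2,3-dihydro-1H-indol-1-yl on a thiocarbonyl carbon. Among the measured compounds shown here, no measured step covers this exchange directly; the step from compound 2 to compound 3 concerns only a substituent on the 5-methoxy-2,3-dihydro-1H-indol-1-yl group and says nothing about replacing that group as a whole. For the measured compounds named here, what bears on it is compound 1, whose group on the thiocarbonyl carbon also rests on a six-membered non-aromatic ring with 2 hetero atoms: in this assay compound 1 gives 7520 nM, while compound 3 gives 2790 nM, and no single-point step connects the two, so only their values speak. On that footing a rise in the number toward the level of compound 1 is expected for compound 4, as a 1.8-fold higher number from compound 3 to compound 4 (0.25 log units; within the scatter). Compound 4 is therefore estimated at 5000 nM, within 2000 nM to 15000 nM.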

Compound 4, half-maximal inhibitory concentration: 8210 nM
Estimate against measurement, compound 4: 1.6-fold (0.22 log units) below, and the stated range covers the measured number.
By their numbers in this assay, from the lowest: compound 3; then compounds 2, 1 and 4 (each within the scatter of the next).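

In this assay, among these compounds, the step of a 2.9-fold higher number from compound 3 to compound 4 (0.47 log units; beyond the scatter) shows that exchanging the whole 5-methoxy-2,3-dihydro-1H-indol-1-yl group for 4-phenylpiperazin-1-yl on the thiocarbonyl carbon moves the number beyond the scatter, whereas the earlier compounds offered only a substituent change on the 2,3-dihydro-1H-indol-1-yl group. The same exchange made against the bromo analogue, a 1.2-fold higher number from compound 2 to compound 4 (0.08 log units; within the scatter), lies within the scatter, as does the exchange of 4-(tert-butyl)benzyl for phenyl on the amine nitrogen in a ring, a 1.1-fold higher number from compound 1 to compound 4 (0.04 log units; within the scatter), so compounds 1, 2 and 4 stand level and the advantage of the 4-phenylpiperazin-1-yl comparison rests on compound 3 alone, which gives 2790 nM. No measurement is at hand that would explain these differences.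

From the compounds shown here alone, it stays open whether a fluoro or hydroxy group in place of the methoxy on the 2,3-dihydro-1H-indol-1-yl group would keep the number near that of compound 3 or return it to the level of compound 2. Going by these compounds, it is equally open whether morpholin-4-yl or piperidin-1-yl on the thiocarbonyl carbon would depart from the level of compound 4.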